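The source may hold more compounds than are shown below. What is called first, only, known or untested is meant among the compounds shown, and "the series" means these compounds.

The measured compounds:
Compound 1 `CCc1cc(Br)ccc1S(=O)(=O)N1CCC(N2CCC(C)CC2)CC1` gives 0.6 nM in a functional assay on DLD-1 cells (Homo sapiens) for antiproliferative activity, read by CellTiter-Glo, with a stated time of 72 h; a higher number here means a weaker inhibitor, a lower number a stronger inhibitor.
Compound 2 `CC1CCN(C2CCN(S(=O)(=O)c3cccc(-c4ccccc4F)c3)CC2)CC1` gives 10 nM in this assay.
Compound 3 `Cc1cc(C)c(S(=O)(=O)N2CCC(N3CCC(CCC#N)CC3)CC2)c(C)c1` reaches only a limit of the assay, > 5000 nM, in this assay.

Among the two numbers shown, compound 2 stands highest: compound 1 gives the lower number, and the gap between the two lies beyond the usual scatter of repeated measurements. The value of compound 3 is a limit of the assay and not a number, and it is not set against the other two here.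

Compound 4 `CC1CCN(C2CCN(S(=O)(=O)c3cccc(-c4ccccc4C(F)(F)F)c3)CC2)CC1` has not yet been measured. It differs from compound 2 in a single place: trifluoromethyl in place of fluoro on an aromatic carbon. Among the compounds with values here, no pair of measured compounds shows this change, so the data give no measured step of this kind to lean on. The step from compound 2 to compound 4 in this assay is therefore expected to be small, in either direction or none beyond the scatter, and the expected step is a 1.5-fold higher number from compound 2 to compound 4 (0.18 log units; within the scatter). Compound 4 is accordingly estimated at 15 nM, with an expected range from 4 nM to 60 nM.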

Compound 4, half-maximal inhibitory concentration: 10 nM
For compound 4 the middle estimate is 1.5-fold (0.18 log units) above the measured one; the range from low to high includes it.
By their numbers in this assay, from the lowest: compound 1; then compounds 2 and 4 (each within the scatter of the next). At a limit, above all of these: compound 3.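

Trifluoromethyl in place of fluoro on an aromatic carbon, ortho to a large group, gives in this assay no change at the digits printed from compound 2 to compound 4 (within the scatter). Within the data shown here, this is the first measured step at this place, and it shows that a group of 4 heavy atoms can stand where a single fluorine stood without a change beyond the scatter. Nothing at hand accounts for this result.

What the compounds shown leave open is how this place responds to a group of another kind, such as an amine, a carboxylic acid or a longer chain, as only fluoro and trifluoromethyl are seen there. Also open, from the compounds shown here alone, is whether the same exchange would read alike on the core of compound 1 or at another carbon of the same ring.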